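Swapping a prenyl chain for a bromobenzyl group

The source may report more compounds than this note shows. Statements on the series, on what has been measured and on what is new or still open speak of the compounds shown alone.

Compound 1 `CC(C)=CCN1C(=O)N(Cc2ccccc2)S(=O)(=O)n2cccc21` carries a 3-methylbut-2-en-1-yl chain on its shared core. For the measured compounds named here, in an ADME assay on MT4 cells (Homo sapiens) for cytotoxicity, read by MTT assay, with a stated time of 5 days (on this read-out higher numbers stand for lower toxicity in this test and lower numbers for higher toxicity in this test), compound 1 gives 226000 nM, the only measured number in this small set. Compound 2 `O=C1N(Cc2ccccc2Cl)c2cccn2S(=O)(=O)N1Cc1cccc(Br)c1` is the other compound tested. In this assay compound 2 reaches only the limit of the assay, reported as > 260000 nM. That limit is the limit of > 260000 nM in this assay, at which 1 of the 2 values shown sits, so one of the two results is a limit rather than a number.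

Compound 3 `O=C1N(Cc2ccccc2Br)c2cccn2S(=O)(=O)N1Cc1ccccc1` has not yet been measured. It differs from compound 1 by 2-bromophenyl in place of 2-methylprop-1-en-1-yl on a saturated chain carbon bound to an amide-type nitrogen in a ring. Going by the values given here, no step between two measured compounds covers this change. The nearest reference is compound 2, which sits at the limit, while compound 1 itself already lies close to that limit. The step from compound 1 to compound 3 is expected to be small, a 1.1-fold higher number from compound 1 to compound 3 (0.04 log units; within the scatter), most likely within the usual scatter or pointing toward lower toxicity. Compound 3 is therefore estimated at 250000 nM in this assay, with a range from 130000 nM to 450000 nM, and a fair chance that the assay again reports only a limit.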

Compound 3, half-maximal cytotoxic concentration: 226000 nM
Beside the measured number, compound 3's estimate is 1.1-fold (0.04 log units) above it; the measured number falls inside the stated range.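

Read in this assay, replacing the 3-methylbut-2-en-1-yl chain of the shared core with 2-bromobenzyl gives no change at the digits printed from compound 1 to compound 3 (within the scatter). For the compounds shown here, this is the first comparison at this place, on a saturated chain carbon bound to an amide-type nitrogen in a ring, and it shows that an open chain with a double bond and a six-membered aromatic ring carrying bromine cannot be told apart on this read-out, something compound 1 alone could not show. Compound 2 adds no second number to this picture, as its result is a limit and not a number: the limit of > 260000 nM in this assay, at which 1 of the 3 values shown sits.

The compounds shown leave open whether an amine or a carboxylic acid at this place would shift the read-out, since both groups compared here have no hydrogen-bond donors or acceptors and no net charge. On these data alone, it also remains open whether the bromine of the 2-bromobenzyl group has any part in this result, or whether a longer chain would give the same reading.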